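From a Pyridin-2-yl Arm to an Aminomethylphenyl Arm

This account rests on a few compounds, and the source may have more. Where it says the series, first, only, none or still open, it means among the compounds named here.

Of the compounds shown here, three have been measured in an assay on Sf9 cells for inhibition of protein deacetylase HDAC6 (Homo sapiens), read by fluorescence; on this read-out higher numbers stand for weaker inhibition and lower numbers for stronger inhibition. Compound 1, `O=C(NO)c1ccc(Cn2nnc(-c3ccccn3)n2)cc1`, gives 9 nM. Compound 2, `Nc1ccc(-c2nnn(Cc3c(F)cc(C(=O)NO)cc3F)n2)cc1`, gives 3 nM, and compound 3, `Cn1c(Cc2ccc(C(=O)NO)cc2)nnc1-c1ccccc1`, gives 17 nM. Among these three, compound 1 holds the second highest number; its nearest neighbour is compound 3, whose number lies within the scatter of repeated measurements, while compound 2 sits furthest away, beyond the scatter and toward stronger inhibition.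

Compound 4, `NCc1ccc(-c2nnn(Cc3ccc(C(=O)NO)cc3)n2)cc1`, has not yet been measured. It differs from compound 1 in one place: 4-(aminomethyl)phenyl in place of pyridin-2-yl on an aromatic carbon. Among the measured compounds shown here, no pair of measured compounds shares exactly this change, so the size of the step cannot be read from a measured step. What the three measured compounds do show is that, despite carrying different aromatic arms and cores, all of them give numbers in a narrow band. The step from compound 1 to compound 4 is therefore expected to be small, with no clear direction beyond the scatter, a 1.1-fold lower number from compound 1 to compound 4 (0.05 log units; within the scatter). Compound 4 is estimated at 8 nM, with a range from 3 nM to 25 nM.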

Compound 4, half-maximal inhibitory concentration: 2 nM
Estimate against measurement, compound 4: 4.0-fold (0.60 log units) above; the whole stated range lies above it.
By their numbers in this assay, from the lowest: compounds 4 and 2 (each within the scatter of the next); then compounds 1 and 3 (each within the scatter of the next).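

In this assay, placing 4-(aminomethyl)phenyl instead of pyridin-2-yl on this aromatic carbon of the shared core gives a 4.5-fold lower number from compound 1 to compound 4 (0.65 log units; beyond the scatter) and moves the number beyond the scatter. Among the compounds shown here, this position therefore responds to the arm it carries, something the earlier compounds could not show, as no two of them differed in one place. The entering arm has a ring of carbon only and a hydrogen-bond donor that the leaving arm lacks, but nothing available explains the step or assigns it to either feature.

On these data alone, it remains open whether the step comes from the ring or from the aminomethyl group, which a 4-(2-aminoethyl)phenyl or a 4-carboxyphenyl arm at this position would help to separate. Also open, as far as these compounds go, is whether the same change would act alike on the core of compound 3.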